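The compounds below may be only part of what the source reports. "The series", "measured", "known", "first", "only" and "open" are said of these compounds alone.

In a functional assay on ACHN cells (Homo sapiens) for inhibition, read by sulforhodamine B assay, with a stated time of 48 h (on this read-out lower numbers stand for higher toxicity in this test and higher numbers for lower toxicity in this test), compound 1 `COc1ccc(-c2cc(/C=C/C(=O)c3ccc(OC)c(OC)c3)[nH]n2)cc1` gives 8710 nM, and compound 3 `COc1cc(C(=O)/C=C/c2cc(-c3cc(OC)c(OC)c(OC)c3)n[nH]2)cc(OC)c1OC` gives 5570 nM; these two values lie within the usual scatter of each other. Compound 2 `COc1cc(-c2cc(/C=C/C(=O)c3ccc(Cl)c(Cl)c3)[nH]n2)cc(OC)c1OC` returns only a limit of the test, > 100000 nM, and its place on the numbers is marked by the limit of > 100000 nM in this assay, at which 1 of the 3 values shown sits, alone. Compound 4 `COc1cc(-c2cc(/C=C/C(=O)c3ccc(F)c(F)c3)[nH]n2)cc(OC)c1OC` differs from compound 2 by 3,4-difluorophenyl in place of 3,4-dichlorophenyl on a carbonyl carbon. Among the measured compounds shown here, with only a limit for compound 2, no measured step in this assay starts from it, and the size of the change that 3,4-difluorophenyl brings in place of 3,4-dichlorophenyl is not known from any measured pair here. Compound 4 is expected to remain weak in this assay, with an estimate of 80000 nM and a likely range from 25000 nM to 250000 nM. The expected step of an at least 1.2-fold lower number from compound 2 to compound 4 (0.09 log units; that floor lies within the scatter) is estimated to stay within or near the scatter.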

Compound 4, concentration lethal to 50% of the cells: > 100000 nM
Compound 4: no number, only a limit; the forecaster's own chance of this, stated with the estimate: 45%; middle value at least 1.2-fold (0.09 log units) from the limit.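

Among the compounds shown here, compound 2 and compound 4 each return only a limit in this assay, so no step between them can be read. The compounds shown leave open what size of change 3,4-difluorophenyl brings in place of 3,4-dichlorophenyl.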